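Shifting the halogen on the phenyl ring of the chain

The source may report more compounds than this note shows. Statements on the series, on what has been measured and on what is new or still open speak of the compounds shown alone.

Compound 1 `O=C(/C=C/c1ccc(Cl)cc1)Nc1ccc2ncnc(Nc3cccc(Cl)c3)c2c1` gives 9.97 ug/mL in a functional assay on B16-F10 cells (Mus musculus) for inhibition, read by MTT assay, with a stated time of 48 h; a lower number here means a stronger inhibitor, a higher number a weaker inhibitor.
Compound 2 `O=C(/C=C/c1ccccc1Cl)Nc1ccc2ncnc(Nc3cccc(Cl)c3)c2c1` gives 1.74 ug/mL in this assay.

Among the measured compounds shown here, compound 2 stands at the lowest of the two numbers; its only neighbour is compound 1, and the step between them is a 5.7-fold lower number from compound 1 to compound 2 (0.76 log units; beyond the scatter). Compound 3 `O=C(/C=C/c1ccc(Br)cc1)Nc1ccc2ncnc(Nc3cccc(Cl)c3)c2c1` has not yet been measured in this assay. It differs from compound 2 in one place: 4-bromophenyl in place of 2-chlorophenyl on a double-bonded chain carbon bound to a double-bonded chain carbon. For the measured compounds named here, the single measured step that bears on this change is a 5.7-fold lower number from compound 1 to compound 2 (0.76 log units; beyond the scatter), in which 4-chlorophenyl was exchanged for 2-chlorophenyl at the same place. Going by the values given here, compound 3 largely reverses that exchange, returning to a halogen on a 4-substituted phenyl, though with bromine rather than chlorine, and no measured pair shows bromine against chlorine. A step back upward, of roughly the size seen before but in the opposite direction, is therefore expected: a 4.0-fold higher number from compound 2 to compound 3 (0.60 log units; beyond the scatter). Compound 3 is accordingly estimated to give about 7 ug/mL in this assay, within a range from 2.5 ug/mL to 20 ug/mL.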

Compound 3, half-maximal inhibitory concentration: 0.75 ug/mL
The estimate for compound 3 lay 9.3-fold (0.97 log units) above the measured number, outside the stated range (below it).
By their numbers in this assay, from the lowest: compound 3; then compound 2; then compound 1.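

On a double-bonded chain carbon bound to a double-bonded chain carbon, the halogen itself turns out to matter: with the ring otherwise unchanged, bromo in place of chloro on an aromatic carbon gives a 13-fold lower number from compound 1 to compound 3 (1.12 log units; beyond the scatter) in this assay. The earlier pair had suggested that 2-chlorophenyl was the better arrangement, yet 4-bromophenyl goes further, with a 2.3-fold lower number from compound 2 to compound 3 (0.37 log units; beyond the scatter), so a halogen on a 4-substituted phenyl is not in itself a disadvantage in these compounds. Nothing available here accounts for the gap between bromo and chloro at this place.

The three compounds do not show how the halogen and its place on the ring act together, since a bromine on the ring of the 2-chlorophenyl kind is absent from them. As far as these compounds go, it also remains open whether the trend with halogen size would extend to iodine, or how a phenyl ring carrying fluorine or a methoxy group would compare.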